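Halogen exchange on the aryl group of compound 3

The source may report more compounds than this note shows. Statements on the series, on what has been measured and on what is new or still open speak of the compounds shown alone.

Measured compounds:
compound 1 `CC[C@H](NC(C)=O)c1cc(Cl)ccc1C1CCN(C(=O)[C@H]2CN(C(C)(C)C)C[C@@H]2c2ccc(F)cc2F)CC1`, 640 nM
compound 2 `CC[C@H](NC(C)=O)c1cc(Cl)ccc1C1CCN(C(=O)[C@H]2CN(C(C)(C)C)C[C@@H]2c2ccc(Cl)cc2Cl)CC1`, 3.3 nM
compound 3 `CC[C@H](NC(C)=O)c1cc(Cl)ccc1C1CCN(C(=O)[C@@H]2CN(C(C)(C)C)C[C@H]2c2ccc(Cl)cc2Cl)CC1`, 17.9 nM

In an assay on CHO cells for displacement of a labelled ligand from Melanocortin receptor 4 (Homo sapiens) (on this read-out higher numbers stand for weaker inhibition and lower numbers for stronger inhibition), compound 3 gives 17.9 nM, the second highest of the three numbers; compound 2 gives 3.3 nM and compound 1 gives 640 nM. Compound 4 `CC[C@H](NC(C)=O)c1cc(Cl)ccc1C1CCN(C(=O)[C@@H]2CN(C(C)(C)C)C[C@H]2c2ccc(Cl)cc2F)CC1` differs from compound 3 by fluoro in place of chloro on an aromatic carbon. The step that bears on this is a 190-fold lower number from compound 1 to compound 2 (2.29 log units; beyond the scatter), where both halogens on that ring changed from fluoro to chloro; compound 4 reverses part of that change, at the aromatic carbon ortho to a large group. The step of a 5.4-fold higher number from compound 2 to compound 3 (0.73 log units; beyond the scatter) is a change of configuration only, as shown by the fact that compounds 2 and 3 differ only in the configuration as drawn, and compound 4 keeps the configuration of compound 3. A rise in the number is therefore expected, smaller than the full halogen step. Compound 4 is expected to give 150 nM, within 35 nM to 700 nM, which is an 8.4-fold higher number from compound 3 to compound 4 (0.92 log units; beyond the scatter).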

Compound 4, half-maximal inhibitory concentration: 6.2 nM
Beside the measured number, compound 4's estimate is 24-fold (1.38 log units) above it; measured number outside the range, below it.
By their numbers in this assay, from the lowest: compounds 2 and 4 (each within the scatter of the next); then compound 3; then compound 1.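

In this assay, going from 2,4-dichlorophenyl to 4-chloro-2-fluorophenyl gives a 2.9-fold lower number from compound 3 to compound 4 (0.46 log units; beyond the scatter), opposite in direction to what a 190-fold lower number from compound 1 to compound 2 (2.29 log units; beyond the scatter) suggested for fluoro. In this configuration, chloro on the aromatic carbon ortho to a large group is therefore not required, and the large halogen step cannot be assigned to that position alone. The two halogen steps are read in different configurations: the fact that compounds 2 and 3 differ only in the configuration as drawn

Open, going by these compounds, is how 4-chloro-2-fluorophenyl reads in the configuration of compound 2. Also open, on these data alone, is how hydrogen, methyl or methoxy in place of this fluoro would read.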